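A few compounds are considered here, and "the series" means these few. Any claim that something is new, unique, unknown or untested is made for them only; others in the source may bear on it.

Compound 1 `CC(c1cc2cccnc2cc1F)n1cnc2ncc(-c3cnn(C)c3)nc21`: 31.3 nM
Compound 2 `CCC(c1cc2cccnc2cc1F)n1cnc2ncc(-c3cnn(C)c3)nc21`: "not determined" (no result reported)
Compound 3 `Cc1c(C(C)n2cnc3ncc(-c4cnn(CCO)c4)nc32)ccc2ncccc12`: 726 nM

All of these come from a functional assay on NCI-H1993 cells (Homo sapiens) for inhibition, read by CCK-8 assay, with a stated time of 72 h; a higher number here means a weaker inhibitor, a lower number a stronger inhibitor. Compound 2 has no number in this assay, so the step begins from an unmeasured point. The nearest guide to compound 2 is compound 1, which looks most like it and gives 31.3 nM. Differing from compound 2 in more than one place, compound 3 gives 726 nM, so it is a looser guide.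

Compound 4 `CCC(c1cc2cccnc2cc1F)n1cnc2ncc(-c3ccc(C(N)=O)c(F)c3)nc21` is the next to be tested. The change is 4-carbamoyl-3-fluorophenyl in place of 1-methyl-1H-pyrazol-4-yl on an aromatic carbon. Within the data shown here, no measured pair shows this swap, so any forecast is uncertain. The expected step is small, with no change beyond the usual scatter and a slight lean towards a weaker inhibitor, taking compound 1 at 31.3 nM as the stand-in starting level. Compound 4 is estimated at 40 nM, with an expected range of 8 nM to 200 nM.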

Compound 4, half-maximal inhibitory concentration: 226 nM
Estimate against measurement, compound 4: 5.7-fold (0.75 log units) below; measured number above the stated range.
By their numbers in this assay, from the lowest: compound 1; then compound 4; then compound 3.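

Among these compounds, no new step can be read: compound 4 gives 226 nM but compound 2, its only one-place neighbour here, has no number to set against it. The effect of swapping 1-methyl-1H-pyrazol-4-yl for 4-carbamoyl-3-fluorophenyl stays open, and no evidence shown bears on this result.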